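Moving the fluorine on the benzyl arm of a hydroxamate

The compounds below may be only part of what the source reports. "The series", "measured", "known", "first", "only" and "open" are said of these compounds alone.

Measured compounds:
Compound 1, `O=C(NO)c1ccc(CN(Cc2ccc(F)cc2)S(=O)(=O)c2c(F)c(F)c(F)c(F)c2F)cc1`, gives 367 nM in an assay on isolated protein for inhibition of histone deacetylase 8 (Homo sapiens), read by mobility shift assay; a lower number here means a stronger inhibitor, a higher number a weaker inhibitor.
Compound 2, `O=C(NO)c1ccc(CN(Cc2ccncc2)S(=O)(=O)c2cc(F)c(F)c(F)c2F)cc1`, gives 581 nM in this assay.
Compound 3, `O=C(NO)c1ccc(CN(Cc2ccc(F)cc2)S(=O)(=O)c2cc(F)c(F)c(F)c2F)cc1`, gives 860 nM in this assay.

Compound 3 has the highest number of the three, so it is the weakest inhibitor shown. Its gap to compound 2 is within the scatter, so no order between those two can be claimed, while the step of a 2.3-fold higher number from compound 1 to compound 3 (0.37 log units; beyond the scatter) lies beyond the scatter.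

Compound 4, `O=C(NO)c1ccc(CN(Cc2ccccc2F)S(=O)(=O)c2cc(F)c(F)c(F)c2F)cc1`, shares every atom with compound 3 and differs only in how they are joined: 2-fluorophenyl in place of 4-fluorophenyl on a saturated chain carbon bound to a sulfonamide nitrogen.

The step that bears on this position is a 1.5-fold higher number from compound 2 to compound 3 (0.17 log units; within the scatter), where a quite different group was exchanged at the same place with no effect beyond the scatter. The step of a 2.3-fold higher number from compound 1 to compound 3 (0.37 log units; beyond the scatter) concerns a different ring and does not speak to this change. A shift no larger than the scatter is therefore expected in this assay, with no clear direction.

Compound 4 is thus expected to give about 800 nM, in a range from 350 nM to 1800 nM, meaning an expected step of a 1.1-fold lower number from compound 3 to compound 4 (0.03 log units; within the scatter).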

Compound 4, half-maximal inhibitory concentration: 241 nM
Estimate against measurement, compound 4: 3.3-fold (0.52 log units) above; measured number outside the range, below it.
By their numbers in this assay, from the lowest: compounds 4, 1, 2 and 3 (each within the scatter of the next, the first and the last beyond it).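

In this assay, the saturated chain carbon bound to the sulfonamide nitrogen proves sensitive to where the fluorine sits on the ring: changing 4-fluorophenyl to 2-fluorophenyl gives a 3.6-fold lower number from compound 3 to compound 4 (0.55 log units; beyond the scatter), with no atom gained or lost. Replacing pyridin-4-yl with 2-fluorophenyl at the same place also goes beyond the scatter, giving a 2.4-fold lower number from compound 2 to compound 4 (0.38 log units; beyond the scatter), whereas the earlier exchange of pyridin-4-yl for 4-fluorophenyl did not, so a change here can matter even though that first exchange showed no clear effect. No measurement shown explains why moving the fluorine has this effect.

As far as these compounds go, it remains open whether a chlorine in place of the fluorine in 2-fluorophenyl, or a cyclohexyl group at this place, would give a similar number. From the compounds shown here alone, it is also open whether the same change from 4-fluorophenyl to 2-fluorophenyl would produce a similar step in compound 1.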